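Swapping an amino ester for tert-butyl on a pyrrole diester

This account rests on a few compounds, and the source may have more. Where it says the series, first, only, none or still open, it means among the compounds named here.

Measured compounds:
- compound 1 `Cc1c(C(=O)OC(C)C(C)(C)C)c[nH]c1C(=O)OC(C)CN(C)C`: 390 nM
- compound 2 `Cc1c(C(=O)OC(C)(C)C)c[nH]c1C(=O)OCC1CC1`: 48 nM
- compound 3 `CCCOC(=O)c1[nH]c(CO)c(C(=O)OC(C)(C)C)c1C`: 7900 nM

In an assay on CHO cells for inhibition of metabotropic glutamate receptor 1 (Rattus norvegicus) (on this read-out higher numbers stand for weaker inhibition and lower numbers for stronger inhibition), compound 1 gives 390 nM, the second highest of the three numbers. Its nearest neighbour is compound 2, which gives 48 nM, a lower number by a margin beyond the scatter; compound 3, at 7900 nM, lies furthest away with a much higher number. Both gaps are beyond the usual scatter, so compound 1 sits clearly between the two.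

Compound 4 `Cc1c(C(=O)OC(C)C(C)(C)C)c[nH]c1C(=O)OC(C)(C)C` has not yet been measured. It differs from compound 1 in one place: tert-butyl in place of 1-((dimethylamino)methyl)ethyl on an oxygen next to a carbonyl group. The rest of the shared core, including the methyl group and the 3,3-dimethylbutan-2-yl ester, is unchanged.

Within the data shown here, no step between two measured compounds matches this change exactly. Among the measured compounds shown here, the only guide is compound 2, which also carries a tert-butyl ester and gives 48 nM. On that basis the step is expected to lower the number, by an amount beyond the scatter, though less certainly than a directly measured pair would allow. Compound 4 is therefore estimated at 80 nM, with a plausible range from 25 nM to 250 nM. The step this implies, a 4.9-fold lower number from compound 1 to compound 4 (0.69 log units; beyond the scatter), is an expectation, not a measurement.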

Compound 4, half-maximal inhibitory concentration: 17 nM
Compound 4: the middle estimate sits 4.7-fold (0.67 log units) above what was measured; measured number below the stated range.
By their numbers in this assay, from the lowest: compound 4; then compound 2; then compound 1; then compound 3.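

In this assay, among these compounds, putting tert-butyl in place of 1-((dimethylamino)methyl)ethyl on an oxygen next to a carbonyl group gives a 23-fold lower number from compound 1 to compound 4 (1.36 log units; beyond the scatter), the first reading of a change at a single place. Among the compounds shown here, it shows that the number responds strongly to what sits on this oxygen, something the earlier compounds could not show, as they differ from one another in more than one place. It also shows that the dimethylamino nitrogen is not required for a low number here: compound 4, whose tert-butyl holds only carbon, gives 17 nM in this assay, while the shared core is unchanged. Nothing available explains the size of this step.

The compounds shown leave open whether the drop in the number comes with tert-butyl itself or with the loss of the dimethylamino group, and an isopropyl ester on this oxygen would separate those two readings. They also leave open how a carboxylic acid, a primary amine or a longer carbon chain would read at the same place.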